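A few compounds are considered here, and "the series" means these few. Any claim that something is new, unique, unknown or untested is made for them only; others in the source may bear on it.

Working notes on the series. Compound 3 `O=C(N/N=C/c1cccnc1)c1cc2cc(Br)ccc2oc1=O` gives 3710 nM in a functional assay on CCRF-CEM cells (Homo sapiens) for antiproliferative activity, read by fluorescence and resazurin assay, with a stated time of 48 h; on this read-out higher numbers stand for weaker inhibition and lower numbers for stronger inhibition. Compound 2 `O=C(N/N=C/c1cccnc1)c1cc2cc([N+](=O)[O-])ccc2oc1=O` carries nitro in place of bromo on an aromatic carbon, and in this assay compound 2 gives 17100 nM; the step is a 4.6-fold higher number from compound 3 to compound 2 (0.66 log units; beyond the scatter). Compound 1 `O=C(N/N=C/c1cc2ccccc2nc1Cl)c1cc2cc(Br)ccc2oc1=O` has a different core, and the difference between the core of compound 1 and the core of compound 3 is not broken down here; in this assay compound 1 gives 7450 nM, which lies within the scatter of compound 3 and is a smaller number than compound 2.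

Compound 4 `O=C(N/N=C/c1cc2ccccc2nc1Cl)c1cc2cc([N+](=O)[O-])ccc2oc1=O` is not yet measured. It carries nitro in place of bromo on an aromatic carbon, the same change that was made from compound 3 to compound 2, with the place described in the same words. Because the change gave a 4.6-fold higher number from compound 3 to compound 2 (0.66 log units; beyond the scatter), a step of similar size is expected from compound 1 to compound 4, estimated as a 4.0-fold higher number from compound 1 to compound 4 (0.60 log units; beyond the scatter). The only support is that single pair, so the range is kept wide. For compound 4 the expected value in this assay is 30000 nM, estimated to lie between 12000 nM and 75000 nM.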

Compound 4, half-maximal inhibitory concentration: 26000 nM
Compound 4: the middle estimate sits 1.2-fold (0.06 log units) above what was measured, and the stated range covers the measured number.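

Nitro in place of bromo on an aromatic carbon gives a 3.5-fold higher number from compound 1 to compound 4 (0.54 log units; beyond the scatter) in this assay and so raises the number on this second core as well. Set beside the earlier step, the two sizes cannot be told apart, so in these two pairs the change carries from one core to the other with much the same size: the same change on two cores in this assay, a 4.6-fold higher number (0.66 log units; beyond the scatter) from compound 3 to compound 2 and a 3.5-fold higher number (0.54 log units; beyond the scatter) from compound 1 to compound 4, 1.3-fold (0.12 log units) apart, within the scatter of two such steps

This rests on two cores, one pair of groups and one assay, so it does not show that the step would hold on any further core, and it gives no reason for the higher number with nitro.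

Open, going by these compounds, is how other groups on the same aromatic carbon would compare with bromo and nitro, for instance an amine, a carboxylic acid or a methoxy group. Also open is which part of the difference between the core of compound 1 and the core of compound 3 matters in this assay, since the two cores differ in more than one place and the compounds shown do not separate those parts.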